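The source may hold more compounds than are shown below. What is called first, only, known or untested is meant among the compounds shown, and "the series" means these compounds.

Values in an ADME assay on SH-SY5Y cells (Homo sapiens) for cytotoxicity, read by MTT assay, with a stated time of 72 h; a higher number here means a weaker inhibitor, a lower number a stronger inhibitor:
- Compound 1 `O=C(CN1CCN(C(=O)c2cccc(Cl)c2)CC1)N1CCN(CCCc2c[nH]c3ccccc23)CC1`: 120000 nM
- Compound 2 `O=C(CN1CCN(C(=O)c2cccc(Br)c2)CC1)N1CCN(CCCc2c[nH]c3ccccc23)CC1`: 80500 nM

Compound 2, at 80500 nM, lies within the scatter of compound 1. Compound 3 `O=C(CN1CCN(C(=O)c2cccc(F)c2)CC1)N1CCN(CCCc2c[nH]c3ccccc23)CC1` follows from compound 2 by one exchange: fluoro in place of bromo on an aromatic carbon. For the measured compounds named here, the only measured step bearing on it is also a halogen exchange, a 1.5-fold lower number from compound 1 to compound 2 (0.17 log units; within the scatter), and it stays within the scatter. No step beyond the scatter is therefore expected in this assay, and no direction is firmly indicated. The expected step is a 1.4-fold higher number from compound 2 to compound 3 (0.14 log units; within the scatter). For compound 3 the estimated value is 110000 nM, with an expected range of 60000 nM to 220000 nM.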

Compound 3, half-maximal inhibitory concentration: 165000 nM
Beside the measured number, compound 3's estimate is 1.5-fold (0.18 log units) below it; measured number inside the range.
By their numbers in this assay, from the lowest: compounds 2, 1 and 3 (each within the scatter of the next, the first and the last beyond it).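

In this assay fluoro in place of bromo on this aromatic carbon gives a 2.0-fold higher number from compound 2 to compound 3 (0.31 log units; beyond the scatter) and so modestly passes the scatter, whereas fluoro in place of chloro gives a 1.4-fold higher number from compound 1 to compound 3 (0.14 log units; within the scatter) and stays within it. Among these three halogens, then, only the bromo and fluoro pair separates, and only just. Nothing at hand accounts for this step.

Open, on these data alone, is whether a group other than a halogen at this place, such as methoxy, an amine or a carboxylic acid, would move the number further. Changes elsewhere on the shared core also remain open.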